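Replacing trifluoromethyl with phenyl in a low-clearance compound

A few compounds are considered here, and "the series" means these few. Any claim that something is new, unique, unknown or untested is made for them only; others in the source may bear on it.

Going by the values given here, in an ADME assay (liver) for pharmacokinetics, with Liver microsome (Rattus norvegicus) as the target, read by LC-MS, using microsomes, tested at 2 uM (a lower number here means slower removal, a higher number faster removal of the compound), compound 1 (`O=C(N[C@@H]1CCCC[C@H]1O)c1cnc(OC2CCCCC2)c(-c2ccc(Cl)cc2)c1`) gives 0.662 mL/min/kg, and compound 2 (`O=C(N[C@@H]1CCCC[C@H]1O)c1cnc(OCC(F)(F)F)c(-c2ccc(Cl)cc2)c1`) gives 0.023 mL/min/kg, the lower of the two numbers measured so far. Among the compounds with values here, only one measured step bears on what comes next: a 29-fold lower number from compound 1 to compound 2 (1.46 log units; beyond the scatter). This large step, beyond the scatter, came with 2,2,2-trifluoroethyl in place of cyclohexyl on an oxygen on an aromatic ring. Compound 3 (`O=C(N[C@@H]1CCCC[C@H]1O)c1cnc(OCc2ccccc2)c(-c2ccc(Cl)cc2)c1`) alters that same group: phenyl in place of trifluoromethyl on a saturated chain carbon bound to an oxygen on an aromatic ring. This turns 2,2,2-trifluoroethyl into benzyl, which, like the cyclohexyl of compound 1, carries a six-membered ring. With so little data, the expectation is only a rough one: a move back up towards compound 1 at 0.662 mL/min/kg. The expected change is a large rise, a 13-fold higher number from compound 2 to compound 3 (1.12 log units; beyond the scatter). For compound 3 the estimate is 0.3 mL/min/kg, with an expected range from 0.07 mL/min/kg to 1 mL/min/kg.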

Compound 3, clearance: 0.02 mL/min/kg
Compound 3: the middle estimate sits 15-fold (1.18 log units) above what was measured; the whole stated range lies above it.
By their numbers in this assay, from the lowest: compounds 3 and 2 (each within the scatter of the next); then compound 1.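

In this assay, phenyl in place of trifluoromethyl gives a 1.2-fold lower number from compound 2 to compound 3 (0.06 log units; within the scatter), so in these compounds a number this low does not depend on fluorine atoms in this group. A six-membered ring alone does not bring back the higher number of compound 1 either: benzyl in place of cyclohexyl on an oxygen on an aromatic ring gives a 33-fold lower number from compound 1 to compound 3 (1.52 log units; beyond the scatter). Nothing available explains why these groups behave this way.

Benzyl differs from cyclohexyl both in having an aromatic ring and in having a saturated chain carbon bound to the oxygen, so cyclohexylmethyl would be needed to tell these two features apart. On these data alone, it also remains open whether a longer chain such as 2-phenylethyl, or an amine on the phenyl ring, would keep the number this low.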